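The source may report more compounds than this note shows. Statements on the series, on what has been measured and on what is new or still open speak of the compounds shown alone.

Working notes on the series. Among the measured compounds shown here, compound 1 `COc1cc(-c2nn(-c3cccc(NC(=O)c4cccc(C(F)(F)F)c4)c3)cc2-c2ccncc2)ccc1Cl` and compound 2 `O=C(Nc1cccc(-n2cc(-c3ccncc3)c(-c3ccc(Cl)c(O)c3)n2)c1)Nc1cc(C(F)(F)F)cc(C(F)(F)F)c1` share a core but differ in more than one place, so no single step joins them. In a functional assay on MDA-MB-435 cells (Homo sapiens) for inhibition, read by sulforhodamine B assay, with a stated time of 48 h (on this read-out lower numbers stand for stronger inhibition of growth and higher numbers for weaker inhibition of growth), compound 1 gives 705 nM, while compound 2 gives 910 nM. Compound 1 holds the lowest of the two numbers, yet the gap to compound 2 lies within the scatter, so the two stand level. Compound 3 `COc1cc(-c2nn(-c3cccc(NC(=O)Nc4ccc(Cl)c(C(F)(F)F)c4)c3)cc2-c2ccncc2)ccc1Cl` is not yet measured; it differs from compound 1 in one place: (4-chloro-3-(trifluoromethyl)phenyl)amino in place of 3-(trifluoromethyl)phenyl on a carbonyl carbon. For the measured compounds named here, the only guide is compound 2, which also carries an amino group on its carbonyl carbon and gives 910 nM, level with compound 1. On that basis the step of a 1.4-fold lower number from compound 1 to compound 3 (0.15 log units; within the scatter) is expected to be small, at most a modest move toward a lower number, and possibly nothing beyond the scatter. Compound 3 is expected to give 500 nM, within a range from 200 nM to 1500 nM.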

Compound 3, concentration for 50% growth inhibition: 683 nM
Beside the measured number, compound 3's estimate is 1.4-fold (0.14 log units) below it; measured number inside the range.
By their numbers in this assay, from the lowest: compounds 3, 1 and 2 (each within the scatter of the next).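

In this assay, among the compounds shown here, the swap of 3-(trifluoromethyl)phenyl for (4-chloro-3-(trifluoromethyl)phenyl)amino on the carbonyl carbon gives a 1.0-fold lower number from compound 1 to compound 3 (0.01 log units; within the scatter), the first reading at this position in which only one place differs. The larger entering group brings a chlorine, a nitrogen and a hydrogen-bond donor, and the two compounds still stand level, so this place on the carbonyl carbon tolerates that combined change in this read-out. No supporting measurement bears on this result.

As far as these compounds go, the amino group and the chlorine enter together here, and whether each alone would leave the number level remains open. Also open, from the compounds shown here alone, is how this place responds to a group of another kind, such as a carboxylic acid or a morpholine in place of the aryl ring.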